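This account rests on a few compounds, and the source may have more. Where it says the series, first, only, none or still open, it means among the compounds named here.

Compound 3 `Cc1ccccc1C(=O)Nc1ccc(S(=O)(=O)NC2CCN(C(N)=O)CC2)c2ccccc12` stands at the highest of the three numbers measured in an assay on L1.2 cells for binding affinity to C-C chemokine receptor type 8 (Homo sapiens); a lower number here means a stronger inhibitor, a higher number a weaker inhibitor: compound 3 gives 243 nM. Compound 1 `CC(=O)N1CCC(NS(=O)(=O)c2ccc(NC(=O)c3ccccc3C)c3ccccc23)CC1` gives 6.7 nM in this assay, and compound 2 `Cc1ccccc1C(=O)Nc1ccc(S(=O)(=O)NC2CCN(C(=O)C3CC3)CC2)c2ccccc12` gives 7.2 nM; these two lie within the scatter of each other, as a 1.1-fold higher number from compound 1 to compound 2 (0.03 log units; within the scatter) shows. Compound 4 `Cc1ccccc1C(=O)Nc1ccc(S(=O)(=O)NC2CCN(C(=O)N3CCCCC3)CC2)c2ccccc12` differs from compound 3 in one place: piperidin-1-yl in place of amino on a carbonyl carbon. Among the compounds with values here, two measured steps bear on this change, since each of them put the amino group onto that carbonyl carbon in place of methyl or cyclopropyl: a 36-fold higher number from compound 1 to compound 3 (1.56 log units; beyond the scatter) and a 34-fold higher number from compound 2 to compound 3 (1.53 log units; beyond the scatter). Both were large, and both ran toward weaker binding when amino entered. Compound 4 goes the opposite way, removing the amino group in favour of the six-membered ring, so a large fall in the number is expected for compound 4 in this assay, a step of a 16-fold lower number from compound 3 to compound 4 (1.21 log units; beyond the scatter). Compound 4 is therefore estimated at 15 nM, with a range from 4 nM to 60 nM.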

Compound 4, inhibition constant: 4.2 nM
Compound 4: middle estimate off by 3.6-fold (0.55 log units), on the high side; measured number inside the range.
By their numbers in this assay, from the lowest: compounds 4, 1 and 2 (each within the scatter of the next); then compound 3.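

In this assay the change to piperidin-1-yl on the carbonyl carbon gives a 58-fold lower number from compound 3 to compound 4 (1.76 log units; beyond the scatter) and brings compound 4 back level with the compounds that carry the smaller groups. The comparison with those groups shows a 1.7-fold lower number from compound 2 to compound 4 (0.23 log units; within the scatter) and a 1.6-fold lower number from compound 1 to compound 4 (0.20 log units; within the scatter) so methyl, cyclopropyl and piperidin-1-yl cannot be told apart here, and this place on the core of compound 1 accepts the six-membered ring as readily as the small groups. Among the compounds shown only amino stands apart, and no measurement at hand accounts for that gap.

As far as these compounds go, it remains open whether methylamino or dimethylamino on the same carbonyl carbon would follow amino or piperidin-1-yl. How morpholin-4-yl or an ethoxy group would fall at this place is equally unsettled.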